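A few compounds are considered here, and "the series" means these few. Any claim that something is new, unique, unknown or untested is made for them only; others in the source may bear on it.

Compound 1 `Oc1cccc(NCCCN2CCN(c3ccccc3)CC2)c1` stands lowest of the three numbers in an assay on HEK293 cells for displacement of a labelled ligand from 5-hydroxytryptamine receptor 7 (Homo sapiens), read by scintillation counting, with a stated time of 30 min; a higher number here means a weaker inhibitor, a lower number a stronger inhibitor: compound 1 gives 10.1 nM. Compound 2 `NC(=O)c1cccc(NCCCN2CCN(c3ccccc3)CC2)c1` gives 63.3 nM and compound 3 `COC(=O)c1cccc(NCCCN2CCN(c3ccccc3)CC2)c1` gives 77.9 nM. Both measured steps from compound 1 replace the substituent on the aromatic ring: a 6.3-fold higher number from compound 1 to compound 2 (0.80 log units; beyond the scatter), and a 7.7-fold higher number from compound 1 to compound 3 (0.89 log units; beyond the scatter). Between the two replacements the change is small: a 1.2-fold higher number from compound 2 to compound 3 (0.09 log units; within the scatter).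

Compound 4 `O=S(=O)(c1ccccc1)N(CCCN1CCN(c2ccccc2)CC1)c1cccc(O)c1` differs from compound 1 at a different place: phenylsulfonyl in place of hydrogen on a nitrogen on an aromatic ring. Going by the values given here, the aromatic hydroxy of compound 1 is kept in compound 4, and none of the measured steps touches this nitrogen, so neither step from compound 1 nor the step from compound 2 to compound 3 bears directly on the change. Nothing in the measured set shows how this place responds to a substituent; the direction is therefore uncertain. A higher number than that of compound 1 is expected, of moderate size, and the range is kept wide to cover both a flat outcome and a larger loss. The expected step is a 4.0-fold higher number from compound 1 to compound 4 (0.60 log units; beyond the scatter). Compound 4 is thus estimated at 40 nM, with a range from 8 nM to 300 nM.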

Compound 4, inhibition constant: 12.1 nM
The estimate for compound 4 lay 3.3-fold (0.52 log units) above the measured number; the measured number falls inside the stated range.
By their numbers in this assay, from the lowest: compounds 1 and 4 (each within the scatter of the next); then compounds 2 and 3 (each within the scatter of the next).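

In this assay, going by these compounds alone, the nitrogen on an aromatic ring is a place that no earlier step had touched, and it accepts phenylsulfonyl in place of hydrogen with a 1.2-fold higher number from compound 1 to compound 4 (0.08 log units; within the scatter), so compound 1 and compound 4 cannot be told apart despite the 9 heavy atoms and the six-membered aromatic ring that enter. Among the compounds shown, the two places therefore read differently: replacing the hydroxy gives a 6.3-fold higher number from compound 1 to compound 2 (0.80 log units; beyond the scatter) and a 7.7-fold higher number from compound 1 to compound 3 (0.89 log units; beyond the scatter), both beyond the scatter, while the hydrogen on this nitrogen can be replaced with the hydroxy kept and the number stays within the scatter of that of compound 1. No measured evidence here accounts for this difference between the two places.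

On these data alone, it remains open whether smaller groups on this nitrogen, such as methyl or acetyl, or a phenylsulfonyl carrying a further substituent such as methoxy or chlorine on its ring, would read the same way. Also open, as far as these compounds go, is whether phenylsulfonyl on this nitrogen would keep the same step with carbamoyl or methoxycarbonyl on the aromatic ring in place of the hydroxy.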